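A few compounds are considered here, and "the series" means these few. Any claim that something is new, unique, unknown or untested is made for them only; others in the source may bear on it.

Measured compounds:
compound 1, `Cc1ccc(C)c(C(Nc2ccccn2)c2ccc3cccnc3c2O)c1`, 730 nM
compound 2, `Cc1ccnc(NC(c2ccccc2C)c2ccc3cccnc3c2O)c1`, > 40000 nM

Compound 1 sits at 730 nM in an assay for inhibition of protein disulfide-isomerase (Homo sapiens), with a stated time of 1 h; a lower number here means a stronger inhibitor, a higher number a weaker inhibitor. For compound 2 only a limit of the assay is reported in this assay, > 40000 nM, so where it truly lies is not known beyond that; this is the limit of > 40000 nM in this assay, at which 1 of the 2 values shown sits. Compound 3, `Cc1ccnc(NC(c2cc(C)ccc2C)c2ccc3cccnc3c2O)c1`, has not yet been measured. It differs from compound 2 by methyl in place of hydrogen on an aromatic carbon, the change reading 2-methylphenyl to 2,5-dimethylphenyl, with the entering methyl meta to a large group and para to a methyl group. For the measured compounds named here, no measured pair isolates this change: compound 1 also carries the 2,5-dimethylphenyl, but its pyridine part differs as well, so its value and that of compound 2 show only that the two compounds stand far apart. Compound 3 is therefore expected to gain somewhat over compound 2, a step of an at least 1.6-fold lower number from compound 2 to compound 3 (0.20 log units; that floor lies within the scatter), while remaining a weak inhibitor. The estimate for compound 3 in this assay is 25000 nM, within 4000 nM to 40000 nM.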

Compound 3, half-maximal inhibitory concentration: > 40000 nM
Compound 3 ended at the assay's limit; the forecaster's own chance of this, stated with the estimate: 55%; middle value at least 1.6-fold (0.20 log units) from the limit.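

In this assay the added methyl of the 2,5-dimethylphenyl brings no visible gain: compound 3, like compound 2, stands at a limit of the assay, so the step between them cannot be read. The informative comparison is new, since a single methyl in place of hydrogen on an aromatic carbon gives an at least 54-fold higher number from compound 1 to compound 3 (1.73 log units; beyond the scatter), which shows that the 2,5-dimethylphenyl alone does not secure the strength seen in compound 1. Reading of the 2-methylphenyl against the 2,5-dimethylphenyl stops here: the limit of > 40000 nM in this assay, at which 2 of the 3 values shown sit.

The compounds shown leave open what this change does in the setting of compound 1, where a value could be read rather than a limit. They also leave open whether a fluorine, a methoxy or an amine in place of the methyl that separates compound 3 from compound 1 would keep any inhibition.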